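Urea series: aryl variation on the amide-type nitrogen

A few compounds are considered here, and "the series" means these few. Any claim that something is new, unique, unknown or untested is made for them only; others in the source may bear on it.

Three compounds have numbers in an assay on CHO cells for displacement of a labelled ligand from transient receptor potential cation channel subfamily V member 1 (Homo sapiens), read by scintillation counting, with a stated time of 60 min; on this read-out lower numbers stand for stronger inhibition and higher numbers for weaker inhibition. Compound 1 `CC(C(=O)NCc1ccc(C(F)(F)F)cc1N1CCC(Cc2ccccc2)(N(C)C)CC1)c1ccc(NS(C)(=O)=O)c(F)c1` gives 3.79 nM. Compound 2 `CN(C)C1(Cc2ccccc2)CCN(c2cc(C(F)(F)F)ccc2CNC(=O)Nc2ccc(NS(C)(=O)=O)c(F)c2)CC1`, which carries the shared urea core of the rest of the set, gives 1160 nM. Compound 3 `CN(C)C1(Cc2ccccc2)CCN(c2cc(C(F)(F)F)ccc2CNC(=O)Nc2ccc(CO)c(F)c2)CC1` gives 27.9 nM; it stands second of the three, its number lying beyond the scatter from compound 1 on one side and from compound 2 on the other. Among the compounds with values here, the one single-point step measured so far, a 42-fold lower number from compound 2 to compound 3 (1.62 log units; beyond the scatter), shows that the group on the aryl ring attached to the amide-type nitrogen moves the read-out strongly.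

Compound 4 `CN(C)C1(Cc2ccccc2)CCN(c2cc(C(F)(F)F)ccc2CNC(=O)Nc2ccc3ccncc3c2)CC1` is not yet measured. It differs from compound 3 by isoquinolin-7-yl in place of 3-fluoro-4-(hydroxymethyl)phenyl on an amide-type nitrogen. Within the data shown here, no measured step covers this change: the only step in the set, from compound 2 to compound 3, swaps one substituent for another on the same phenyl, whereas here the whole 3-fluoro-4-(hydroxymethyl)phenyl gives way to isoquinolin-7-yl and the hydrogen-bond donor is lost. The large size of the step from compound 2 to compound 3 only says that this position is sensitive; its direction cannot be carried over. For compound 4 the expected step in this assay is therefore modest, a 1.9-fold lower number from compound 3 to compound 4 (0.27 log units; within the scatter), with wide uncertainty. Compound 4 is estimated at 15 nM, range 3 nM to 80 nM.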

Compound 4, inhibition constant: 7.33 nM
For compound 4 the middle estimate is 2.0-fold (0.31 log units) above the measured one; the range from low to high includes it.
By their numbers in this assay, from the lowest: compounds 1 and 4 (each within the scatter of the next); then compound 3; then compound 2.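

In this assay, replacing the whole 3-fluoro-4-(hydroxymethyl)phenyl with isoquinolin-7-yl on the amide-type nitrogen gives a 3.8-fold lower number from compound 3 to compound 4 (0.58 log units; beyond the scatter), so this position tolerates exchange of the entire aryl group and not only of a substituent on the same phenyl. The entering group has 0 hydrogen-bond donors, so among the urea compounds shown, the hydroxyl of compound 3 is not needed for a low number, and the same exchange made on the methanesulfonamido-bearing phenyl gives a 160-fold lower number from compound 2 to compound 4 (2.20 log units; beyond the scatter), the widest span yet seen at this position. The data offer nothing that explains either step.

The exchange alters several features at once, the fluorine, the hydroxymethyl, the added aromatic ring and the ring nitrogen, and the compounds shown do not separate their contributions. On these data alone, it also remains open how this position would read with a naphthyl group, which keeps the two rings of carbon only, or with a phenyl carrying an amine or a carboxylic acid.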